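Enlarging the amide acyl group on the shorter chain

This account rests on a few compounds, and the source may have more. Where it says the series, first, only, none or still open, it means among the compounds named here.

For the measured compounds named here, compound 2 `CC(=O)NCCCCN1CCN(c2ccc(Cl)cc2)CC1` gives 1260 nM in an assay on HEK293 cells for binding affinity to D(4) dopamine receptor (Homo sapiens), read by radioligand binding (on this read-out higher numbers stand for weaker inhibition and lower numbers for stronger inhibition), the highest of the two numbers measured so far. Compound 1 `CC(C)(C)C(=O)NCCCCCN1CCN(c2ccc(Cl)cc2)CC1` gives 126 nM in this assay. Compound 3 `CCC(C)(C)C(=O)NCCCCN1CCN(c2ccc(Cl)cc2)CC1` carries 1,1-dimethylpropyl in place of methyl on a carbonyl carbon. Going by the values given here, the one measured step bearing on this, a 10-fold higher number from compound 1 to compound 2 (1.00 log units; beyond the scatter), bundles a change of the acyl group with a change in chain length, so only part of it can be credited to the acyl group. A lower number is therefore expected for compound 3, a step of about a 5.0-fold lower number from compound 2 to compound 3 (0.70 log units; beyond the scatter), smaller than that measured step. Compound 3 is estimated at 250 nM, within 80 nM to 800 nM.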

Compound 3, inhibition constant: 15.9 nM
Beside the measured number, compound 3's estimate is 16-fold (1.20 log units) above it, outside the stated range (below it).
By their numbers in this assay, from the lowest: compound 3; then compound 1; then compound 2.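

With the chain held constant, the acyl group alone carries a large effect in this assay: 1,1-dimethylpropyl in place of methyl on a carbonyl carbon gives a 79-fold lower number from compound 2 to compound 3 (1.90 log units; beyond the scatter) on the shorter chain. The longer chain of compound 1 is not needed for a low number, as a 7.9-fold lower number from compound 1 to compound 3 (0.90 log units; beyond the scatter) shows, though that step also changes the acyl group. Nothing available here accounts for the size of these steps.

As far as these compounds go, how that last step divides between acyl group and chain length stays open. So does the effect of a carboxylic acid or an amine on the acyl group.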